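The source may report more compounds than this note shows. Statements on the series, on what has been measured and on what is new or still open speak of the compounds shown alone.

Measured in a physicochemical assay for solubility, at pH 7.4; on this read-out lower numbers stand for lower solubility and higher numbers for higher solubility:
- compound 1 `CSc1ccc(NC(=O)Nc2cc(C)nc3ccccc23)cc1`: 1300 nM
- compound 2 `Cc1cc(NC(=O)Nc2ccc(F)cc2)c2ccccc2n1`: 3700 nM
- compound 3 `Cc1cc(NC(=O)Nc2ccc(OC(F)(F)F)cc2)c2ccccc2n1`: 300 nM

Compound 3 has the lowest number of the three. Next comes compound 4 `COc1ccc(NC(=O)Nc2cc(C)nc3ccccc23)cc1`, with methyl in place of trifluoromethyl on an oxygen on an aromatic ring. Going by the values given here, no measured step makes this exact exchange. The closest evidence is two steps that arrive at trifluoromethoxy: a 4.3-fold lower number from compound 1 to compound 3 (0.64 log units; beyond the scatter), and a 12-fold lower number from compound 2 to compound 3 (1.09 log units; beyond the scatter). Both went down, so leaving trifluoromethoxy is expected to raise the number in this assay, by a modest to large step. The expected step is a 6.7-fold higher number from compound 3 to compound 4 (0.82 log units; beyond the scatter). Compound 4 is estimated at 2000 nM, with an expected range of 800 nM to 5000 nM.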

Compound 4, solubility: 19800 nM
The estimate for compound 4 lay 9.9-fold (1.00 log units) below the measured number, and the stated range ends below it.
By their numbers in this assay, from the lowest: compound 3; then compound 1; then compound 2; then compound 4.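

Read in this assay the exchange of trifluoromethyl for methyl on this oxygen gives a 66-fold higher number from compound 3 to compound 4 (1.82 log units; beyond the scatter) as the largest step in the series, so two groups attached through oxygen sit at opposite ends of the four compounds. Methoxy also stands clear of fluoro and methylsulfanyl, with a 5.4-fold higher number from compound 2 to compound 4 (0.73 log units; beyond the scatter) and a 15-fold higher number from compound 1 to compound 4 (1.18 log units; beyond the scatter) in the same direction.

From the compounds shown here alone, whether a hydroxyl, an amine or a longer alkoxy chain in this place would sit nearer methoxy or trifluoromethoxy stays open. No available measurement bears on the reason for the size of these steps.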